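Anilino for methyl on the thiadiazole: an expected step

The compounds below may be only part of what the source reports. "The series", "measured", "known", "first", "only" and "open" are said of these compounds alone.

Measured so far:
Compound 1, `COc1ccc(Nc2nnc(-c3cc(-c4ccc(F)cc4F)ccc3O)o2)cc1`: 35.3%
Compound 2, `CNc1nnc(-c2cc(-c3ccc(F)cc3F)ccc2O)o1`: 41.4%
Compound 3, `CNc1nnc(-c2cc(-c3ccc(F)cc3F)ccc2O)s1`: 45.4%

Of the compounds shown here, three sharing one core have been tested in a functional assay on the whole organism (strain BALB/c) for inhibition, with Mus musculus as the target, read by paw edema, with a stated time of 4 h, at a dose of 50 mg/kg by the oral route; on this read-out higher numbers stand for more inhibition at the one dose given (going by the name of the read-out) and lower numbers for less inhibition. Compound 2 gives 41.4%, and compound 3 gives 45.4%, the highest of the three numbers; compound 1 gives 35.3%.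

Two single changes connect them. From compound 2 to compound 1 the change is 4-methoxyphenyl in place of methyl on a nitrogen on an aromatic ring, and it made the step of a number 6.1 percentage points lower from compound 2 to compound 1 (within the scatter). From compound 2 to compound 3 the change in the core is 5-(methylamino)-1,3,4-thiadiazol-2-yl in place of 5-(methylamino)-1,3,4-oxadiazol-2-yl on an aromatic carbon, and it made the step of a number 4 percentage points higher from compound 2 to compound 3 (within the scatter). Only the gap between compound 3 and compound 1 lies beyond the scatter.

Compound 4, `COc1ccc(Nc2nnc(-c3cc(-c4ccc(F)cc4F)ccc3O)s2)cc1`, has not yet been measured in this assay. It differs from compound 3 by 4-methoxyphenyl in place of methyl on a nitrogen on an aromatic ring, the same change that was made from compound 2 to compound 1, at the same place, now on the core of compound 3. Going by the values given here, that earlier step is the only guide, and it was small. Compound 4 is therefore expected to sit a little under compound 3, with an estimated step of a number 6.4 percentage points lower from compound 3 to compound 4 (within the scatter). Compound 4 is estimated at 39%, with a range from 28% to 50% that reflects the ordinary scatter of this measurement.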

Compound 4, a percentage reported as inhibition, in the whole organism at one dose (the size of the read-out at that dose, not a potency): 55.3%
Compound 4: middle estimate off by 16.3 percentage points, on the low side; the measured number lies above the stated range.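

On the core of compound 3, with 4-methoxyphenyl in place of methyl on the nitrogen, the result in this assay is a number 9.9 percentage points higher from compound 3 to compound 4 (within the scatter), so this step alone does not separate the two compounds. Set beside the earlier step, though, the same change does not carry over unaltered from one core to the other: the same change on two cores in this assay, a number 6.1 percentage points lower (within the scatter) from compound 2 to compound 1 and a number 9.9 percentage points higher (within the scatter) from compound 3 to compound 4, 16 percentage points apart, beyond the scatter of two such steps This shows that, for these two cores, a step read on one was a poor guide to the step on the other, but it does not show why the steps differ, and two cores give no rule for any further core.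

The compounds shown carry only methyl or 4-methoxyphenyl on that nitrogen, which leaves open whether a plain phenyl, a 4-chlorophenyl or a longer chain such as butyl would part the two cores in the same way. On these data alone, it also remains open whether a free amine, with neither group on the nitrogen, would give steps that agree between the cores or differ as these two do.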